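The compounds below may be only part of what the source reports. "The series", "measured", "known", "first", "only" and "open" are said of these compounds alone.

Compound 1 `CCOC(=O)CCCCCOc1cccc(CN(C(=O)c2ccc(-c3cnc(OC)nc3OC)cc2)C(C)C)c1`: > 26000 nM
Compound 2 `CCOC(=O)CCCCCOc1cccc(CN(C(=O)c2ccc(-c3cccc(OCc4ccccc4)c3)cc2)C(C)C)c1`: > 26000 nM

Both results come from an ADME assay on HepG2 cells (Homo sapiens) for cytotoxicity, read by CellTiter-Glo and resazurin assay, with a stated time of 72 h; on this read-out higher numbers stand for an effect only at larger amounts of compound and lower numbers for an effect already at smaller amounts. In this assay compound 1 gives > 26000 nM, which is a limit of the assay and not a number. In the same assay compound 2 gives > 26000 nM, again a limit rather than a number. Compound 2 therefore stands at the limit of > 26000 nM in this assay, at which 2 of the 2 values shown sit, and no value shown for it is a number. Compound 3 `CCOC(=O)CCCCCOc1cccc(CN(C(=O)c2ccc(-c3cccc(C(F)(F)F)c3)cc2)C(C)C)c1` has not yet been measured in this assay. It differs from compound 2 in one place: trifluoromethyl in place of benzyloxy on an aromatic carbon. Among the measured compounds shown here, no step between two measured compounds is given, so there is no measured guide for this change. Compound 3 is expected to show a step that the limit leaves unreadable from compound 2 to compound 3, a step of no size beyond the scatter. This expectation rests on compound 2 standing at the limit of > 26000 nM in this assay, at which 2 of the 2 values shown sit. The estimate for compound 3 is 30000 nM, in a range from 10000 nM to 100000 nM, most likely reported once more as a limit.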

Compound 3, half-maximal effective concentration: > 26000 nM
Compound 3: a limit, no number; the forecaster's own chance of this, stated with the estimate: 75%; the middle value is on the limit's open side.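

In this assay no step can be read among compound 1, compound 2 and compound 3; each result is a limit and not a number. The compounds shown leave open at what concentration any of the three would reach a half-maximal effect, and whether they differ at all.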